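This account rests on a few compounds, and the source may have more. Where it says the series, first, only, none or still open, it means among the compounds named here.

Of the compounds shown here, two sharing one core have been measured so far in a physicochemical assay for solubility, in phosphate buffer, measured as kinetic solubility; a lower number here means a less soluble compound, a higher number a more soluble compound. For the measured compounds named here, compound 1 (`CC(C)C(c1ccc(-c2ccc3cccc(F)c3c2)[nH]c1=O)N1CCN/C1=N\C#N`) gives 25200 nM, and compound 2 (`CC(C)C(Nc1nccs1)c1ccc(-c2ccc3cccc(F)c3c2)[nH]c1=O`) gives 16100 nM, so compound 2 stands within the scatter of the only other number available. Compound 3 (`CC(C)C(Cc1nnn[nH]1)c1ccc(-c2ccc3cccc(F)c3c2)[nH]c1=O`), not yet measured, carries (1H-tetrazol-5-yl)methyl in place of (1,3-thiazol-2-yl)amino on a saturated chain carbon bound to an aromatic carbon and a saturated chain carbon. Going by the values given here, one measured step bears on this change, at the same place: a 1.6-fold lower number from compound 1 to compound 2 (0.19 log units; within the scatter), which stays within the scatter. Among the compounds with values here, no measured compound carries the (1H-tetrazol-5-yl)methyl group, so this guidance is thin. A step to a higher number in this assay, slightly beyond the scatter, is expected: a 2.2-fold higher number from compound 2 to compound 3 (0.34 log units; beyond the scatter). For compound 3 the estimate is 35000 nM, with an expected range of 12000 nM to 100000 nM.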

Compound 3, solubility: 27300 nM
For compound 3 the middle estimate is 1.3-fold (0.11 log units) above the measured one; low and high end bracket the measured number.
By their numbers in this assay, from the lowest: compounds 2, 1 and 3 (each within the scatter of the next).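

At this saturated chain carbon, a third group now stands on the shared core: in this assay, (1H-tetrazol-5-yl)methyl in place of (1,3-thiazol-2-yl)amino gives a 1.7-fold higher number from compound 2 to compound 3 (0.23 log units; within the scatter) and leaves the reading close to that of the other thiazole-free compound, with a 1.1-fold higher number from compound 1 to compound 3 (0.03 log units; within the scatter) for the exchange of the non-aromatic ring group. All three groups differ in ring type and in their count of ring hetero atoms, yet no step among them lies beyond the scatter, so this position has so far shown no measurable change in this read-out. Nothing at hand speaks to why these numbers stay so close.

From the compounds shown here alone, whether a carboxylic acid, an amine or a longer alkyl chain on this carbon would give a step beyond the scatter stays open. So does whether these exchanges would read the same on a different core.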